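A few compounds are considered here, and "the series" means these few. Any claim that something is new, unique, unknown or untested is made for them only; others in the source may bear on it.

Measured so far:
compound 1, `Cc1cc(/C=C/C#N)cc(C)c1Oc1nc(Nc2ccc(N3CCCC(N)C3)cc2)nc2ccsc12`: 3820 nM
compound 2, `Cc1cc(/C=C/C#N)cc(C)c1Oc1nc(Nc2ccc(N3CCCC(NS(N)(=O)=O)C3)cc2)nc2sccc12`: a limit, > 217000 nM

Both were tested in an ADME assay on MT4 cells (Homo sapiens) for cytotoxicity, read by MTT assay, with a stated time of 5 days; a lower number here means that less compound is tolerated, a higher number that more compound is tolerated. Compound 1 gives 3820 nM. For compound 2 the assay reports only a limit, > 217000 nM, which is the limit of > 217000 nM in this assay, at which 1 of the 2 values shown sits. Compound 3, `Cc1cc(/C=C/C#N)cc(C)c1Oc1nc(Nc2ccc(N3CCCC(N)C3)cc2)nc2sccc12`, has not yet been measured. It differs from compound 2 by hydrogen in place of sulfamoyl on an amine nitrogen. Compound 1 carries the same 3-aminopiperidin-1-yl group and sits far from the limit. Compound 3 is expected in that region, since compound 1 gives 3820 nM. The expected step is a large decrease, an at least 36-fold lower number from compound 2 to compound 3 (1.55 log units; beyond the scatter), beyond the usual scatter. The estimate for compound 3 is 6000 nM, with a range from 1500 nM to 40000 nM.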

Compound 3, half-maximal cytotoxic concentration: 4610 nM
Compound 3: the middle estimate sits 1.3-fold (0.11 log units) above what was measured, and the stated range covers the measured number.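

With the core held the same, replacing sulfamoyl with hydrogen on this amine nitrogen gives, in this assay, an at least 47-fold lower number from compound 2 to compound 3 (1.67 log units; beyond the scatter). Among these compounds, this is the first direct comparison at this position, and it links the free amino group to much less compound being tolerated than the sulfamoylamino group. The value for compound 2 is a limit, not a number: the limit of > 217000 nM in this assay, at which 1 of the 3 values shown sits.

Only sulfamoyl and hydrogen can be compared on this nitrogen. Where an acetyl or a methyl group would fall in this assay stays open.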